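A few compounds are considered here, and "the series" means these few. Any claim that something is new, unique, unknown or untested is made for them only; others in the source may bear on it.

Series notes, measured in a functional assay on SW480 cells (Homo sapiens) for antiproliferative activity, read by MTT assay, with a stated time of 48 h; on this read-out lower numbers stand for stronger inhibition and higher numbers for weaker inhibition:

- compound 1 `CC(=O)OC/C1=C/C[C@](C)(CCC=C(C)C)/C=C/[C@@H](OC(=O)C=C(C)C)[C@](C)(O)/C=C/C1=O`: 2950 nM
- compound 2 `COC/C1=C/C[C@](C)(CCC=C(C)C)/C=C/[C@@H](OC(=O)C=C(C)C)[C@](C)(OC)/C=C/C1=O`: 14600 nM

Of the two measured compounds, compound 2 has the higher number, at 14600 nM, and so shows the weaker inhibition. Its gap to compound 1 lies beyond the scatter.

Next in line is compound 3 `COC/C1=C/C[C@](C)(CCC=C(C)C)/C=C/[C@@H](OC(=O)C=C(C)C)[C@](C)(O)/C=C/C1=O`, to be measured in this assay. Going from compound 2 to compound 3, methoxy becomes hydroxy: hydrogen in place of methyl on an oxygen on a saturated carbon. This is hydrogen in place of methyl on an oxygen on a saturated carbon.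

Among the measured compounds shown here, no measured pair differs in one place, so the size of this change has no direct precedent. For the measured compounds named here, the only guide is the spread of the two values, and the only lower number available is that of compound 1, at 2950 nM. A moderate move towards a lower number is therefore expected, though a result within the scatter of compound 2 would not be surprising. The expected change is a 2.2-fold lower number from compound 2 to compound 3 (0.35 log units; beyond the scatter), an estimate with wide uncertainty. For compound 3 the estimated value is 6500 nM, with an expected range of 2800 nM to 15000 nM.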

Compound 3, half-maximal inhibitory concentration: 3850 nM
Estimate against measurement, compound 3: 1.7-fold (0.23 log units) above, and the stated range covers the measured number.
By their numbers in this assay, from the lowest: compounds 1 and 3 (each within the scatter of the next); then compound 2.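

In this assay, among the compounds shown here, methoxy to hydroxy on an oxygen on a saturated carbon gives a 3.8-fold lower number from compound 2 to compound 3 (0.58 log units; beyond the scatter) and is the first single-place reading at this position, where the step lies beyond the scatter and hydroxy carries the lower number. The second single-place reading is methyl in place of acetyl on an oxygen on a saturated carbon, which gives a 1.3-fold higher number from compound 1 to compound 3 (0.12 log units; within the scatter) and lies within the scatter, so this assay does not separate these two groups at that oxygen. No measurement at hand accounts for either result.

As far as these compounds go, whether an ethoxy or an acetoxy group in place of the hydroxy of compound 3 would read closer to compound 3 or to compound 2 remains open, as does the effect of a free hydroxy or an amine at the oxygen that carries the methyl in compound 3 and the acetyl in compound 1. From the compounds shown here alone, the methoxy to hydroxy step also rests on a single pair, so whether it keeps its size with acetyl at that other oxygen is unknown.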